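Ester to Primary Amide on the Triazole Side Chain

This account rests on a few compounds, and the source may have more. Where it says the series, first, only, none or still open, it means among the compounds named here.

Measured compounds:
- compound 1 `Cc1cc(C)c(Oc2cc(Nc3ccc(C#N)cc3)ncc2C(=O)NCc2cn(Cc3ccccc3[N+](=O)[O-])nn2)c(C)c1`: in an ADME assay on MT4 cells (Homo sapiens) for cytotoxicity, read by MTT assay, with a stated time of 5 days (on this read-out lower numbers stand for higher toxicity in this test and higher numbers for lower toxicity in this test), compound 1 gives > 212000 nM, which is a limit of the assay and not a number.
- compound 2 `Cc1cc(C)c(Oc2cc(Nc3ccc(C#N)cc3)ncc2C(=O)NCc2cn(Cc3ccccc3F)nn2)c(C)c1`: compound 2 gives > 222000 nM, again a limit rather than a number.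
- compound 3 `CCOC(=O)Cn1cc(CNC(=O)c2cnc(Nc3ccc(C#N)cc3)cc2Oc2c(C)cc(C)cc2C)nn1`: compound 3 gives 9530 nM.

Compound 3 therefore holds the only actual number shown; the two further values are limits, as the limit of > 212000 nM in this assay, at which 1 of the 3 values shown sits, and the limit of > 222000 nM in this assay, at which 1 of the 3 values shown sits, record. The measured steps of an at least 22-fold lower number from compound 1 to compound 3 (1.34 log units; beyond the scatter) and an at least 23-fold lower number from compound 2 to compound 3 (1.36 log units; beyond the scatter) both replace an aromatic group on the saturated chain carbon bound to the aromatic nitrogen with ethoxycarbonyl, and both run toward the lower, more toxic, number of compound 3.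

Compound 4 `Cc1cc(C)c(Oc2cc(Nc3ccc(C#N)cc3)ncc2C(=O)NCc2cn(CC(N)=O)nn2)c(C)c1` differs from compound 3 in a different place: amino in place of ethoxy on a carbonyl carbon. For the measured compounds named here, the ethoxycarbonyl that carries the measured steps is kept only as far as the carbonyl carbon, so none of the measured steps speaks to this change, and no direction can be read from them. Compound 4 is therefore estimated with a wide range, at 30000 nM, somewhere between 8000 nM and 150000 nM, which would mean an expected step of a 3.1-fold higher number from compound 3 to compound 4 (0.50 log units; beyond the scatter).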

Compound 4, half-maximal cytotoxic concentration: 24000 nM
The estimate for compound 4 lay 1.3-fold (0.10 log units) above the measured number, and the stated range covers the measured number.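

In this assay, for the compounds shown here, amino in place of ethoxy on a carbonyl carbon gives a 2.5-fold higher number from compound 3 to compound 4 (0.40 log units; beyond the scatter), so the far end of this side chain moves the read-out toward lower toxicity in this test; the earlier steps showed only what happens when ethoxycarbonyl replaces a whole aromatic group. Carbamoyl in place of either aromatic group still leaves the number well down, with an at least 9.2-fold lower number from compound 2 to compound 4 (0.96 log units; beyond the scatter) and an at least 8.8-fold lower number from compound 1 to compound 4 (0.94 log units; beyond the scatter), and both sizes are only bounds, since the aromatic partners stand at limits of the assay and not at numbers; the drop seen with ethoxycarbonyl is therefore only partly undone when ethoxy goes, and the two carbonyl side chains stay on the lower side of both aromatic ones. What is recorded here gives no cause for either change.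

Only this one swap on the carbonyl carbon is shown, so it stays open how a carboxylic acid or a methylamino group in place of amino would read. On these data alone, it also stays open whether a longer chain between the aromatic nitrogen and the carbonyl would keep these numbers.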